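The source may hold more compounds than are shown below. What is called first, only, known or untested is meant among the compounds shown, and "the series" means these compounds.

In a functional assay on DU-145 cells (Homo sapiens) for inhibition, read by MTT assay, with a stated time of 72 h (on this read-out lower numbers stand for stronger inhibition and higher numbers for weaker inhibition), compound 1 (`COC(=O)CCCCCCC(=O)Nc1cccc(OS(=O)(=O)C2CC3OC2C(c2ccc(O)cc2)=C3c2ccc(O)cc2)c1`) gives 19300 nM and compound 2 (`Cc1ccc(OS(=O)(=O)C2CC3OC2C(c2ccc(NC(=O)CCCCCCC(=O)O)cc2)=C3c2ccc(O)cc2)cc1`) gives 80800 nM as the higher of the two numbers, a gap beyond the usual scatter. Compound 3 (`O=C(O)CCCCCCC(=O)Nc1ccc(C2=C(c3ccc(O)cc3)C3CC(S(=O)(=O)Oc4ccc(F)cc4)C2O3)cc1`) differs from compound 2 in one place (fluoro in place of methyl on an aromatic carbon), with fluoro in place of methyl on an aromatic carbon. Within the data shown here, no measured pair shows this change, so no step beyond the scatter is expected in this assay and the estimated 1.3-fold lower number from compound 2 to compound 3 (0.13 log units; within the scatter) stays small. Compound 3 is estimated at 60000 nM with a range from 22000 nM to 150000 nM as the expected span.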

Compound 3, half-maximal inhibitory concentration: > 100000 nM
Compound 3: a limit, no number; the forecaster's own chance of this, stated with the estimate: 10%; at least 1.6-fold (0.22 log units) between middle value and limit.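

Among these compounds, replacing 4-methylphenoxy with 4-fluorophenoxy gives the first reading of this change at this place, and it brings no stronger inhibition. In this assay compound 3 gives > 100000 nM, which is a limit of the assay and not a number. The step is an at least 1.2-fold higher number from compound 2 to compound 3 (0.09 log units; that floor lies within the scatter), so its true size stays unknown: the limit of > 100000 nM in this assay, at which 1 of the 3 values shown sits.

From the compounds shown here alone, whether an amine or a methoxy group at this place would lower the number stays open. With this single pair, the same change cannot be read on any other compound.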